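The source may hold more compounds than are shown below. What is called first, only, known or untested is meant among the compounds shown, and "the series" means these compounds.

Measured in an ADME assay on PBMC cells (Homo sapiens) for cytotoxicity; on this read-out lower numbers stand for higher toxicity in this test and higher numbers for lower toxicity in this test:
- compound 1 `COc1cccc(OC(c2ccc(C(F)(F)F)cc2)C2CCN(C(C)CCNC(=O)c3c(Cl)cncc3Cl)CC2)n1` gives 32700 nM
- compound 2 `CCO/N=C(/c1ccc(Br)cc1)C1CCN(C(C)CCNC(=O)c2c(Cl)cncc2Cl)CC1` gives 33800 nM
- compound 3 `CC(CCNC(=O)c1c(Cl)cncc1Cl)N1CCC(C(=O)c2ccc(Br)cc2)CC1` gives 189000 nM

Compound 1 shows the lowest of the three numbers in this assay, but the value of compound 2 lies within the scatter of it, so the two cannot be ordered. Compound 3 stands apart: its number is higher than that of compound 1 by more than the scatter, and it is the only one of the three with a ketone in place of the ether or oxime link at the piperidine. Among the measured compounds shown here, no pair of these three differs in a single place, so none of the gaps can be tied to one structural change.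

Compound 4 `CC(CCNC(=O)c1c(Cl)cncc1Cl)N1CCC(C(Oc2cc(Cl)ccn2)c2ccc(C(F)(F)F)cc2)CC1` is not yet measured. It differs from compound 1 in one place:

4-chloropyridin-2-yl in place of 6-methoxypyridin-2-yl on an oxygen on a saturated carbon

The shared core and the trifluoromethyl-bearing aryl are kept; only the pyridine on the ether oxygen changes. For the measured compounds named here, nothing among the measured compounds isolates such a swap, so the expectation rests on the closeness of compound 1 and compound 2 despite a larger difference between them. A step of about a 1.1-fold lower number from compound 1 to compound 4 (0.04 log units; within the scatter) is expected, that is none beyond the scatter. Compound 4 is estimated at 30000 nM, with a range of 12000 nM to 80000 nM.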

Compound 4, half-maximal cytotoxic concentration: 4260 nM
Compound 4: middle estimate off by 7.0-fold (0.85 log units), on the high side, and the stated range ends above it.
By their numbers in this assay, from the lowest: compound 4; then compounds 1 and 2 (each within the scatter of the next); then compound 3.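

The pyridine on the ether oxygen is not a neutral place in this assay: 4-chloropyridin-2-yl in place of 6-methoxypyridin-2-yl gives a 7.7-fold lower number from compound 1 to compound 4 (0.89 log units; beyond the scatter), while the shared core and the trifluoromethyl-bearing aryl stay the same. Among the compounds shown here, this is the first gap that can be tied to a single change, and the closeness of compound 1 and compound 2 gave no sign that this place could move the number so far. Nothing measured here accounts for the step.

The compounds shown leave open whether the step follows the loss of the methoxy group, the arrival of the chlorine or the place of the substituent on the pyridine; a 4-methoxypyridin-2-yl or an unsubstituted pyridin-2-yl on the same oxygen would separate these. Also open, on these data alone, is whether the same swap gives a similar step with a nitrile in place of the trifluoromethyl on the aryl.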